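The source may hold more compounds than are shown below. What is called first, only, known or untested is meant among the compounds shown, and "the series" means these compounds.

Compound 1 `CN(Cc1ccc(OCCCN)cc1)c1nc2ccc(Oc3ccccc3)cc2s1` gives 49000 nM
Compound 2 `CN(Cc1ccc(OCCCNC(=N)N)cc1)c1nc2ccc(Oc3cccc(C(F)(F)F)c3)cc2s1` gives 202000 nM
Compound 3 `CN(Cc1ccc(OCCCN)cc1)c1nc2ccc(Oc3ccc(O)cc3)cc2s1` gives 117000 nM

In an assay on SH-SY5Y cells for inhibition of Voltage-dependent N-type calcium channel subunit alpha-1B (Homo sapiens), read by FLIPR and calcium flux, with stated times of 600 s and 300 s, in the presence of a further agent that is not named here (a lower number here means a stronger inhibitor, a higher number a weaker inhibitor), compound 3 stands second highest of the three numbers: compound 2 lies close to it, within the scatter, while compound 1 gives a lower number beyond the scatter. Compound 4 `CN(Cc1ccc(OCCCN)cc1)c1nc2ccc(Oc3cccc(C(F)(F)F)c3)cc2s1` is not yet measured and differs from compound 3 by 3-(trifluoromethyl)phenyl in place of 4-hydroxyphenyl on an oxygen on an aromatic ring. Among the compounds with values here, one measured step bears on this change: a 2.4-fold higher number from compound 1 to compound 3 (0.38 log units; beyond the scatter), which the move to compound 4 undoes in part, as the hydroxy leaves. Within the data shown here, no measured pair isolates the trifluoromethyl on its own; compound 2 carries the same 3-(trifluoromethyl)phenoxy but differs elsewhere in the molecule as well, so its number alone does not settle the matter. On this basis a modest step to a lower number is expected for compound 4, a 1.6-fold lower number from compound 3 to compound 4 (0.19 log units; within the scatter), close to the edge of the scatter. Compound 4 is therefore estimated at 75000 nM, with a range from 30000 nM to 200000 nM.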

Compound 4, half-maximal inhibitory concentration: 77000 nM
For compound 4 the middle estimate is 1.0-fold (0.01 log units) below the measured one; the measured number falls inside the stated range.
By their numbers in this assay, from the lowest: compounds 1, 4, 3 and 2 (each within the scatter of the next, the first and the last beyond it).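

In this assay, 3-(trifluoromethyl)phenyl in place of 4-hydroxyphenyl on an oxygen on an aromatic ring gives a 1.5-fold lower number from compound 3 to compound 4 (0.18 log units; within the scatter), so this exchange does not separate the two compounds. Trifluoromethyl in place of hydrogen on an aromatic carbon can now be read alone and gives a 1.6-fold higher number from compound 1 to compound 4 (0.20 log units; within the scatter), also within the scatter, while the hydroxy step gave a 2.4-fold higher number from compound 1 to compound 3 (0.38 log units; beyond the scatter), beyond it. With the 3-(trifluoromethyl)phenoxy held constant, a hydrogen atom in place of the group of 3 heavy atoms on the amine nitrogen gives a 2.6-fold lower number from compound 2 to compound 4 (0.42 log units; beyond the scatter), which isolates that change and places it beyond the scatter.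

Nothing measured here gives a reason for any of these steps. Also open, on these data alone, is how a carboxylic acid or a nitrile in place of trifluoromethyl, or a longer chain carrying the amine, would read in this assay.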